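Sulfonyl replacement on the side chain of compound 2

The source may hold more compounds than are shown below. What is called first, only, known or untested is meant among the compounds shown, and "the series" means these compounds.

Among the compounds with values here, compound 2 `NC(=O)c1ccc(OCCCN2CCC(C(c3ccc(F)cc3)c3ccc(F)cc3)CC2)cc1` gives 31.6 nM in a functional assay (aorta) with Oryctolagus cuniculus as the target (a higher number here means weaker binding, a lower number tighter binding), and stands highest of the two numbers measured so far; compound 1 `COc1cc(C(C)=O)ccc1OCCCCN1CCC(C(c2ccc(F)cc2)c2ccc(F)cc2)CC1` gives 2.51 nM in this assay, a gap that lies beyond the scatter. Compound 3 `O=S(=O)(CCCN1CCC(C(c2ccc(F)cc2)c2ccc(F)cc2)CC1)c1ccccc1` has not yet been measured; relative to compound 2 the change is phenylsulfonyl in place of 4-carbamoylphenoxy on a saturated chain carbon, three bonds along the chain from an amine nitrogen in a ring. Within the data shown here, no measured step of this kind exists to lean on, so the expectation for compound 3 is a modest move toward a lower number, a 2.1-fold lower number from compound 2 to compound 3 (0.32 log units; beyond the scatter), not clearly beyond the scatter. Compound 3 is estimated at 15 nM in this assay, within 4 nM to 60 nM.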

Compound 3, dissociation constant: 20 nM
For compound 3 the middle estimate is 1.3-fold (0.12 log units) below the measured one, and the stated range covers the measured number.
By their numbers in this assay, from the lowest: compound 1; then compounds 3 and 2 (each within the scatter of the next).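

In this assay, phenylsulfonyl in place of 4-carbamoylphenoxy on a saturated chain carbon gives a 1.6-fold lower number from compound 2 to compound 3 (0.20 log units; within the scatter) and so no readable change. This place therefore accepts the exchange, even though the entering group carries no hydrogen-bond donor and the leaving group does. No data on hand explain this result.

Open, on these data alone, is whether a carboxylic acid or an amine on the phenyl ring of phenylsulfonyl would move the number beyond the scatter. Also open, as far as these compounds go, is how a longer chain carrying the same sulfonyl group would read in this assay here.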